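A few compounds are considered here, and "the series" means these few. Any claim that something is new, unique, unknown or untested is made for them only; others in the source may bear on it.

Measured so far in a functional assay on U-373MG ATCC cells for inhibition, with U373 MG (Homo sapiens) as the target, read by MTT assay, with a stated time of 7 days; on this read-out lower numbers stand for stronger inhibition of growth and higher numbers for weaker inhibition of growth:
- Compound 1 `NC(=O)c1ncn2c(=O)n(Cc3ccccc3)nnc12`: > 50000 nM, a limit
- Compound 2 `COc1ccc(Cn2nnc3c(C(N)=O)ncn3c2=O)cc1`: > 50000 nM, a limit
- Compound 3 `Cc1noc(Cn2nnc3c(C(N)=O)ncn3c2=O)n1`: > 50000 nM, a limit

Compound 1 has no exact number, as its > 50000 nM is a limit. The whole set looks the same, with the limit of > 50000 nM in this assay, at which 3 of the 3 values shown sit. This gives a flat starting point, with no measured growth inhibition to compare against.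

Compound 4 `CC[C@@H](c1ccccc1)n1nnc2c(C(N)=O)ncn2c1=O` keeps the core of compound 1 and has one change: ethyl in place of hydrogen on a saturated chain carbon bound to an aromatic carbon and an aromatic nitrogen.

Among the compounds with values here, two measured steps bear on this change, and neither offers a size to carry over. Within the data shown here, the first is a step that the two limits leave unreadable from compound 1 to compound 2, and the second is a step that the two limits leave unreadable from compound 1 to compound 3. Each runs from one limit to another, so neither shows how far a change can move the result, or in which direction.

With only these steps to go on, no step beyond the usual scatter is expected in this assay, and a further limit is the likeliest outcome. The expected step is a number no higher from compound 1 to compound 4 (the limit leaves the size open). The estimated value for compound 4 is 50000 nM, with an expected range from 25000 nM to 100000 nM.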

Compound 4, concentration for 50% growth inhibition: > 50000 nM
Compound 4: only a limit was reported (the forecaster's own chance of this, stated with the estimate: 80%); the middle value lies on the limit itself.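

In this assay compound 4 gives > 50000 nM, which is a limit and not a number. Compound 1 also has only a limit, and the step between compound 1 and compound 4 cannot be read. The compounds shown leave open how far any of these changes moves growth inhibition, or in which direction: the limit of > 50000 nM in this assay, at which 4 of the 4 values shown sit.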